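The source may report more compounds than this note shows. Statements on the series, on what has been measured and on what is new or still open speak of the compounds shown alone.

Compound 3 `O=C(O)c1ccc(CN2CCC[C@H](OCc3cc(Cl)cc(Cl)c3)[C@@H]2c2ccccc2)cn1` carries a 6-carboxypyridin-3-yl group on the shared core. In an assay on isolated protein for activation of cGMP-dependent protein kinase 1 (Homo sapiens), read by ADP-Glo, with stated times of 120 min and 40 min (on this read-out higher numbers stand for an effect only at larger amounts of compound and lower numbers for an effect already at smaller amounts), compound 3 gives only a limit of the assay, > 200000 nM, so its true value is not known. Compound 1 `Clc1cc(Cl)cc(CO[C@H]2CCCN(Cc3cccnc3)[C@H]2c2ccccc2)c1` gives 112000 nM in this assay, and compound 2 `Cn1cc(CN2CCC[C@H](OCc3cc(Cl)cc(Cl)c3)[C@@H]2c2ccccc2)cn1` gives 110000 nM; the step of a 1.0-fold lower number from compound 1 to compound 2 (0.01 log units; within the scatter) shows the two sit together. The steps of an at least 1.7-fold higher number from compound 1 to compound 3 (0.25 log units; that floor lies within the scatter) and an at least 1.8-fold higher number from compound 2 to compound 3 (0.25 log units; that floor lies within the scatter) bear on the change to compound 4 `COc1cc(C(=O)O)ccc1CN1CCC[C@H](OCc2cc(Cl)cc(Cl)c2)[C@@H]1c1ccccc1`, in which (4-carboxy-2-methoxyphenyl in place of 6-carboxypyridin-3-yl on a saturated chain carbon bound to an amine nitrogen in a ring). Since both steps toward compound 3 end at the limit (the limit of > 200000 nM in this assay, at which 1 of the 3 values shown sits), the carboxy-bearing group of compound 4 is expected to stay in the same weak region, with a step of a number no higher from compound 3 to compound 4 (the limit leaves the size open) not expected to go beyond the scatter. Compound 4 is therefore estimated at 200000 nM, between 80000 nM and 500000 nM.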

Compound 4, half-maximal effective concentration: 62000 nM
Compound 4: the middle estimate sits 3.2-fold (0.51 log units) above what was measured, outside the stated range (below it).
By their numbers in this assay, from the lowest: compounds 4, 2 and 1 (each within the scatter of the next). At a limit, above all of these: compound 3.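

In this assay, a carboxy group on the aromatic ring does not by itself keep a compound at the limit, as the change of group gives an at least 3.2-fold lower number from compound 3 to compound 4 (0.50 log units; beyond the scatter). Compound 3 has only a limit of the assay, not a number: the limit of > 200000 nM in this assay, at which 1 of the 4 values shown sits. The groups without a carboxy sit no differently from 4-carboxy-2-methoxyphenyl, with a 1.8-fold lower number from compound 2 to compound 4 (0.25 log units; within the scatter) and a 1.8-fold lower number from compound 1 to compound 4 (0.26 log units; within the scatter).

This change swaps the ring and adds a methoxy group at once, so the compounds shown do not tell which of the two matters. A 4-carboxyphenyl group would separate them.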